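This account rests on a few compounds, and the source may have more. Where it says the series, first, only, none or still open, it means among the compounds named here.

Measured compounds:

compound 1 `Cc1ccccc1/C=N\NC(=S)N(Cc1ccccc1)Cc1ccccc1` — 167000 nM
compound 2 `C=CCN(CC=C)C(=S)N/N=C\c1ccc(Cl)cc1` — 213000 nM
compound 3 `C/C(=N/NC(=S)N(Cc1ccccc1)Cc1ccccc1)c1ccc(O)cc1` — 160000 nM

All three values come from an ADME assay on Vero cells (Chlorocebus sabaeus) for cytotoxicity, read by MTT assay, with a stated time of 72 h; on this read-out higher numbers stand for lower toxicity in this test and lower numbers for higher toxicity in this test. Compound 1 gives 167000 nM and sits second highest of the three numbers; its gap to compound 3 and its gap to compound 2 both fall within the scatter, so the three measured compounds cannot be told apart on this read-out.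

The untested compound 4 `S=C(N/N=C\c1ccc(Cl)cc1)N(Cc1ccccc1)Cc1ccccc1` keeps the shared core of compound 1 and carries one change: 4-chlorophenyl in place of 2-methylphenyl on a carbon with a double bond to nitrogen. Among the measured compounds shown here, no measured pair shows this change on its own. As compound 2, which also carries the 4-chlorophenyl group, gives 213000 nM, a step no larger than the scatter is expected in this assay, in no particular direction.

Compound 4 is expected to give about 180000 nM, within 100000 nM to 320000 nM. The expected step of a 1.1-fold higher number from compound 1 to compound 4 (0.03 log units; within the scatter) is thus estimated as essentially flat.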

Compound 4, half-maximal cytotoxic concentration: 159000 nM
Beside the measured number, compound 4's estimate is 1.1-fold (0.05 log units) above it, and the stated range covers the measured number.
By their numbers in this assay, from the lowest: compounds 4, 3, 1 and 2 (each within the scatter of the next).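

In this assay, 4-chlorophenyl in place of 2-methylphenyl on a carbon with a double bond to nitrogen gives a 1.1-fold lower number from compound 1 to compound 4 (0.02 log units; within the scatter). Among the compounds shown here, this is the first direct reading of a single change at this place, and with the rest of the shared core held constant, the step does not separate the two groups. No available evidence bears on a cause for this result.

Still open, as far as these compounds go, is whether an amine, a carboxylic acid or a longer chain on this carbon would give a step beyond the scatter.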